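A few compounds are considered here, and "the series" means these few. Any claim that something is new, unique, unknown or untested is made for them only; others in the source may bear on it.

Measured so far in an assay on isolated protein (strain Sprague-Dawley) for inhibition of Amine oxidase [flavin-containing] A (Rattus norvegicus), read by spectrophotometry, with a stated time of 5 min, tested at 10 uM; a lower number here means less inhibition, a higher number more inhibition at the concentration tested (going by the name of the read-out):
- compound 1 `CCCOc1cc(=O)oc2cc(OCc3ccccc3)ccc12`: compound 1 gives 0%
- compound 2 `CCOc1cc(=O)oc2cc(OCc3cccc(F)c3)ccc12`: compound 2 gives 25%
- compound 3 `COCOc1cc(=O)oc2cc(OCc3cccc(Cl)c3)ccc12`: compound 3 gives 23%

Compound 3 stands second highest of the three numbers. Its nearest neighbour is compound 2, whose number is slightly higher but within the scatter, so no order between the two can be read. Its furthest neighbour is compound 1, whose number lies beyond the scatter below it.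

Compound 4 `CN(C)C(=O)COc1cc(=O)oc2cc(OCc3cccc(Cl)c3)ccc12` carries the same core with one change against compound 3: dimethylcarbamoyl in place of methoxy on a saturated chain carbon bound to an oxygen on an aromatic ring. Among the measured compounds shown here, no measured pair shows this change, and the data give no footing for a shift in either direction. The step from compound 3 to compound 4 in this assay is therefore expected to stay within the scatter, a number 1 percentage points lower from compound 3 to compound 4 (within the scatter). Compound 4 is estimated at 22%, within 2% to 45%.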

Compound 4, a percentage reported as inhibition, at one concentration (the size of the read-out at that concentration, not a potency): 10%
For compound 4 the middle estimate is 12 percentage points above the measured one; low and high end bracket the measured number.
By their numbers in this assay, from the lowest: compounds 1 and 4 (each within the scatter of the next); then compounds 3 and 2 (each within the scatter of the next).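

In this assay, among the compounds shown here, dimethylcarbamoyl in place of methoxy on a saturated chain carbon bound to an oxygen on an aromatic ring gives a number 13 percentage points lower from compound 3 to compound 4 (beyond the scatter) and is the first step read at this position. The number therefore responds to the group placed here, though a single pair shows no trend. Nothing measured bears on why the number falls.

From the compounds shown here alone, whether an amine, a carboxylic acid or a longer chain here would keep the number near that of compound 3 stays open. A primary amide would test whether the drop follows the carbonyl or the two methyl groups on the nitrogen.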